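A few compounds are considered here, and "the series" means these few. Any claim that something is new, unique, unknown or untested is made for them only; others in the source may bear on it.

Measured so far in a functional assay on MCF7 cells (Homo sapiens) for antiproliferative activity; on this read-out higher numbers stand for weaker inhibition and lower numbers for stronger inhibition:
- compound 1 `N#CN(C(=N)NCCCCCOc1ccccc1)c1ccncc1`: 150 nM
- compound 2 `N#CN/C(=N\CCCCCCCOc1ccccc1)Nc1cccnc1`: 42 nM
- compound 3 `N#CN/C(=N\CCCCCCOc1ccccc1[N+](=O)[O-])Nc1ccncc1`: 6.3 nM

Compound 3 has the lowest number of the three, and its distance to each of the other two lies beyond the scatter. Among the measured compounds shown here, these three compounds differ from one another in more than one place, so no measured pair isolates a single change. For the measured compounds named here, in particular, the data hold no pair that differs only in where the nitro group sits.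

The next compound is compound 4 `N#CN/C(=N\CCCCCCOc1ccc([N+](=O)[O-])cc1)Nc1ccncc1`, which has 4-nitrophenyl in place of 2-nitrophenyl on an oxygen on a saturated carbon. The two compounds have the same atoms, joined differently, and the rest of the structure is unchanged. Going by the values given here, with no measured precedent for this move, the working expectation stays anchored on compound 3 at 6.3 nM, and no step beyond the scatter is expected in this assay, though the uncertainty is wide in both directions. The expected step is a 1.3-fold higher number from compound 3 to compound 4 (0.10 log units; within the scatter). For compound 4 the estimated value is 8 nM, with an expected range of 2 nM to 30 nM.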

Compound 4, half-maximal inhibitory concentration: 120 nM
Compound 4: middle estimate off by 15-fold (1.18 log units), on the low side; measured number outside the range, above it.
By their numbers in this assay, from the lowest: compound 3; then compound 2; then compounds 4 and 1 (each within the scatter of the next).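

In this assay, among the compounds shown here, placing 4-nitrophenyl in place of 2-nitrophenyl on the oxygen gives a 19-fold higher number from compound 3 to compound 4 (1.28 log units; beyond the scatter), the first measured pair that isolates a single change. The two groups have the same atoms and the same counts, so this position distinguishes between the two nitrophenyl isomers, and the change is far from neutral. No measured data at hand explain why the two isomers differ.

On these data alone, it remains open whether a phenyl carrying an amine or a nitrile in place of the nitro group would stay near compound 3 at 6.3 nM or move towards compound 4 at 120 nM. As far as these compounds go, it is also open whether the same step would appear with the different chains of compound 1 and compound 2.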